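Aryl variation on the thiadiazole arm of the series

This account rests on a few compounds, and the source may have more. Where it says the series, first, only, none or still open, it means among the compounds named here.

Compound 1 `CC(C)(C)n1ncc(OCc2nnc(-c3ccc(Cl)cc3)s2)c(Cl)c1=O` carries a 4-chlorophenyl group and in a functional assay on the whole organism for inhibition, with Mythimna separata as the target, with a stated time of 5 days (on this read-out lower numbers stand for an effect already at smaller amounts and higher numbers for an effect only at larger amounts of compound), compound 1 gives 106 ug/mL. Compound 2 `Cc1cc(C)cc(-c2nnc(COc3cnn(C(C)(C)C)c(=O)c3Cl)s2)c1` carries 3,5-dimethylphenyl instead. In this assay compound 2 shows only > 300 ug/mL, which is a limit of the assay and not a number (the limit of > 300 ug/mL in this assay, at which 1 of the 2 values shown sits). The step of an at least 2.8-fold higher number from compound 1 to compound 2 (0.45 log units; beyond the scatter) is thus known only as a lower bound, and compound 2 stands at the weak end of the two values shown.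

Compound 3 `CC(C)(C)n1ncc(OCc2nnc(-c3ccccc3)s2)c(Cl)c1=O` differs from compound 2 by phenyl in place of 3,5-dimethylphenyl on an aromatic carbon. Going by the values given here, the only measured step that bears on this arm is an at least 2.8-fold higher number from compound 1 to compound 2 (0.45 log units; beyond the scatter); it shows that the aryl group on this ring shifts the read-out at least modestly. A move back toward smaller numbers in this assay is expected, an at least 1.5-fold lower number from compound 2 to compound 3 (0.17 log units; that floor lies within the scatter), though compound 2 being a limit leaves its size uncertain. Compound 3 is estimated at 200 ug/mL (range 80 ug/mL to 600 ug/mL) in this assay.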

Compound 3, half-maximal effective concentration: 200 ug/mL
Estimate against measurement, compound 3: no gap at the digits printed, and the stated range covers the measured number.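

In this assay, hydrogen in place of chloro on the aromatic carbon gives a 1.9-fold higher number from compound 1 to compound 3 (0.28 log units; within the scatter), so the chloro group of the 4-chlorophenyl arm is not shown to change the read-out, and the plain phenyl arm serves as a reference for this position. Phenyl in place of 3,5-dimethylphenyl gives an at least 1.5-fold lower number from compound 2 to compound 3 (0.17 log units; that floor lies within the scatter), so the two methyl groups may account for the earlier separation, but this step alone does not establish that. The size of this step stays open because compound 2 is a limit of the assay and not a number: the limit of > 300 ug/mL in this assay, at which 1 of the 3 values shown sits.

Still open, going by these compounds, is whether a single methyl group, as in 3-methylphenyl, is enough to shift the read-out. The compounds shown also give no reading on an amine or a carboxylic acid on this phenyl ring.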